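A few compounds are considered here, and "the series" means these few. Any claim that something is new, unique, unknown or untested is made for them only; others in the source may bear on it.

Working notes on the series, all read in a functional assay on HCT-116 cells (Homo sapiens) for antiproliferative activity, read by MTT assay, with a stated time of 72 h; on this read-out higher numbers stand for weaker inhibition and lower numbers for stronger inhibition. Compound 1 `O=C(CCc1cccc2c1B(O)OC2)Nc1ccc(Cl)cc1` gives 12000 nM, compound 2 `O=C(CCc1cccc2c1B(O)OC2)Nc1ccc(I)cc1` gives 50000 nM, and compound 3 `Cc1ccc(NC(=O)CCc2cccc3c2B(O)OC3)cc1` gives 4500 nM. Compound 3 therefore holds the lowest number of the three, and its steps to both others lie beyond the scatter.

The next change leads to compound 4 `O=C(CCc1cccc2c1B(O)OC2)Nc1cccc(Br)c1`, with 3-bromophenyl in place of 4-methylphenyl on an amide-type nitrogen.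

Among the measured compounds shown here, three measured steps bear on this change. Methyl in place of a halogen lowered the number both times, modestly in a 2.7-fold lower number from compound 1 to compound 3 (0.43 log units; beyond the scatter) and by a large amount in an 11-fold lower number from compound 2 to compound 3 (1.05 log units; beyond the scatter). Iodo in place of chloro gave a modest rise, a 4.2-fold higher number from compound 1 to compound 2 (0.62 log units; beyond the scatter). For the measured compounds named here, no measured compound carries the 3-bromophenyl group, so these steps transfer only loosely. Read in reverse, the smaller methyl step, a 2.7-fold lower number from compound 1 to compound 3 (0.43 log units; beyond the scatter), is taken as the main guide, with the iodo compound marking the possible upper reach.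

A modest step to a higher number is expected in this assay, estimated as a 3.3-fold higher number from compound 3 to compound 4 (0.52 log units; beyond the scatter). The estimated value for compound 4 is 15000 nM, with an expected range of 5000 nM to 50000 nM.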

Compound 4, half-maximal inhibitory concentration: 1400 nM
The estimate for compound 4 lay 11-fold (1.03 log units) above the measured number, outside the stated range (below it).
By their numbers in this assay, from the lowest: compound 4; then compound 3; then compound 1; then compound 2.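

In this assay the 3-bromophenyl group on the amide-type nitrogen takes the series to its lowest number, with a 3.2-fold lower number from compound 3 to compound 4 (0.51 log units; beyond the scatter) and with the change beyond the scatter, so a halogen-bearing phenyl group at this nitrogen is not tied to a higher number than 4-methylphenyl, as compound 1 and compound 2 alone had suggested. The halogen-bearing compounds also spread widely at this one nitrogen, with an 8.6-fold lower number from compound 1 to compound 4 (0.93 log units; beyond the scatter) and the larger 36-fold lower number from compound 2 to compound 4 (1.55 log units; beyond the scatter), showing that the choice of aryl group here can move the number by a large amount while the shared core stays the same. Nothing available gives a measured reason for the drop at compound 4.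

The compounds shown do not separate the effect of the halogen from that of its place on the ring, as compound 4 differs from compound 1 and compound 2 in both. Also open, as far as these compounds go, is how the number would respond to an amine or a carboxylic acid on this phenyl ring, or to a longer chain on the carbonyl carbon.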